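Removing a thiophene ring from two related chain-linked anilides

A few compounds are considered here, and "the series" means these few. Any claim that something is new, unique, unknown or untested is made for them only; others in the source may bear on it.

Compound 1 `CCOc1cc(NC(=O)CCCCC(=O)Nc2cc(-c3ccc(C)s3)ccc2N)cc2c1OCC([N+](=O)[O-])=C2` and compound 2 `CCOc1cc(NC(=O)CCCCC(=O)Nc2ccccc2N)cc2c1OCC([N+](=O)[O-])=C2` share one core and differ in a single spot: hydrogen in place of 5-methylthiophen-2-yl on an aromatic carbon. In an assay on isolated protein for inhibition of protein deacetylase HDAC6 (Homo sapiens), read by fluorescence, with stated times of 10 min and 30 min, tested at 10 uM (on this read-out lower numbers stand for less inhibition and higher numbers for more inhibition at the one concentration tested (going by the name of the read-out)), compound 1 gives 8%, whereas compound 2 gives 68%, a step described as a number 60 percentage points higher from compound 1 to compound 2 (beyond the scatter). Compound 3 `CCOc1cc(NC(=O)CCCCCC(=O)Nc2cc(-c3ccc(C)s3)ccc2N)cc2c1OCC([N+](=O)[O-])=C2` keeps the ring group of compound 1 on a core whose difference from that of compound 1 is not broken down here. In this assay compound 3 gives 36%, which places it between the other two. Compound 4 `CCOc1cc(NC(=O)CCCCCC(=O)Nc2ccccc2N)cc2c1OCC([N+](=O)[O-])=C2` relates to compound 3 as compound 2 relates to compound 1, through the same change at the same place: hydrogen in place of 5-methylthiophen-2-yl on an aromatic carbon. Among the measured compounds shown here, the one earlier instance of this change, a number 60 percentage points higher from compound 1 to compound 2 (beyond the scatter), was large, so a rise is expected here too, though a smaller one is estimated because compound 3 already starts at 36%. The step from compound 3 to compound 4 is therefore expected to be a number 42 percentage points higher from compound 3 to compound 4 (beyond the scatter). Compound 4 is estimated at 78%, most likely between 58% and 95%.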

Compound 4, a percentage reported as inhibition, at one concentration (the size of the read-out at that concentration, not a potency): 57%
The estimate for compound 4 lay 21 percentage points above the measured number, and the stated range ends above it.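

Replacing 5-methylthiophen-2-yl with hydrogen raises the number in this assay on both cores, so the direction of the change carries over, but its size does not: the same change on two cores in this assay, a number 60 percentage points higher (beyond the scatter) from compound 1 to compound 2 and a number 21 percentage points higher (beyond the scatter) from compound 3 to compound 4, 39 percentage points apart, beyond the scatter of two such steps

On the core of compound 3 the change gives a number 21 percentage points higher from compound 3 to compound 4 (beyond the scatter), so a step seen on one core cannot simply be added to another as a fixed amount. With hydrogen in place on both cores, the difference between the cores still shows as a number 11 percentage points lower from compound 2 to compound 4 (beyond the scatter), but these two pairs cannot explain why the size of the change differs, nor show that the direction would hold on any further core.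

The compounds shown leave open how a smaller group at this place, such as a chlorine atom or a methyl group, would compare with hydrogen and 5-methylthiophen-2-yl. They also leave open whether a longer chain would continue the differences seen here, and how the compounds would behave at other concentrations.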